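The source may report more compounds than this note shows. Statements on the series, on what has been measured and on what is new or still open speak of the compounds shown alone.

Working notes on the naphthalenesulfonamide series in an assay on thoracic aorta for binding affinity to Endothelin-1 receptor (Rattus norvegicus); on this read-out lower numbers stand for stronger inhibition and higher numbers for weaker inhibition.

Among the measured compounds shown here, compound 1 `Cc1noc(NS(=O)(=O)c2cccc3ccccc23)c1C` gives 3100 nM in this assay, the lowest of the three numbers so far, though the two others sit within the scatter of it. Compound 2 `Cc1noc(NS(=O)(=O)c2ccc(N)c3ccccc23)c1C` gives 3500 nM and compound 3 `CC(=O)Nc1ccc(S(=O)(=O)Nc2onc(C)c2C)c2ccccc12` gives 3400 nM. The step of a 1.1-fold higher number from compound 1 to compound 2 (0.05 log units; within the scatter) and the step of a 1.1-fold higher number from compound 1 to compound 3 (0.04 log units; within the scatter) both stay inside the scatter, and a 1.0-fold lower number from compound 2 to compound 3 (0.01 log units; within the scatter) likewise shows nothing beyond it. In short, placing a nitrogen substituent on an aromatic carbon of the core has so far left the read-out unchanged.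

Compound 4 `Cc1noc(NS(=O)(=O)c2cccc3c(NC(C)C)cccc23)c1C` differs from compound 1 by isopropylamino in place of hydrogen on an aromatic carbon. This is again a nitrogen substituent on an aromatic carbon of the core, so the steps from compound 1 to compound 2 and from compound 1 to compound 3 are the ones that bear on it; both were flat. For the measured compounds named here, the new group is larger than amino and sits at a place that no measured compound has been probed at, so the expectation carries more uncertainty than those two steps alone would suggest. On the evidence at hand no step beyond the scatter is expected, that is a 1.0-fold lower number from compound 1 to compound 4 (0.01 log units; within the scatter). Compound 4 is therefore estimated at 3000 nM, with a range from 1000 nM to 9000 nM.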

Compound 4, half-maximal inhibitory concentration: 5 nM
Estimate against measurement, compound 4: 600-fold (2.78 log units) above, and the stated range ends above it.
By their numbers in this assay, from the lowest: compound 4; then compounds 1, 3 and 2 (each within the scatter of the next).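

The isopropylamino group, on an aromatic carbon ortho to a fused ring and meta to a fused ring, gives a 620-fold lower number from compound 1 to compound 4 (2.79 log units; beyond the scatter) in this assay, so a substituent on the core of compound 1 can move this read-out by a large margin. The flat steps, a 1.1-fold higher number from compound 1 to compound 2 (0.05 log units; within the scatter) and a 1.1-fold higher number from compound 1 to compound 3 (0.04 log units; within the scatter), therefore do not hold for every nitrogen substituent on an aromatic carbon of the core; compound 4 goes against that earlier picture, and it differs from compound 2 and compound 3 both in the group and in where the group sits, so the contribution of each cannot be separated. Nothing on hand accounts for the size of this step.

The compounds shown leave open whether the nitrogen, the isopropyl part or both carry the effect at this position; an amino, a dimethylamino or an isopropoxy group at the same place would bear on that question. Also open, going by these compounds, is how far the chain on the nitrogen can be changed, for instance to a cyclopentyl group or a longer alkyl chain, with the number staying as low as that of compound 4.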